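A few compounds are considered here, and "the series" means these few. Any claim that something is new, unique, unknown or untested is made for them only; others in the source may bear on it.

Compounds measured so far:

compound 1, `CC1=CC[C@@H]([C@@](C)(O)CCCC(C)(C)NC=S)CC1`: 42500 nM
compound 2, `CC1=CC[C@@H]([C@@](C)(O)CCCC(C)(C)NC(=S)NN)CC1`: a limit, > 100000 nM
compound 3, `CC1=CC[C@@H]([C@@](C)(O)CCCC(C)(C)NC(=S)N/N=C\c2ccccc2)CC1`: 43800 nM

All three share one core and differ only in what hangs on the thiocarbonyl carbon. In a functional assay on UACC-62 cells (Homo sapiens) for cytotoxicity, read by sulforhodamine B assay (on this read-out higher numbers stand for weaker inhibition of growth and lower numbers for stronger inhibition of growth), compound 1 gives 42500 nM. For compound 2 the assay reports only a limit, > 100000 nM. In this assay compound 3 gives 43800 nM, and among the two plain numbers compound 3 and compound 1 sit within the usual scatter of each other, as the step of a 1.0-fold higher number from compound 1 to compound 3 (0.01 log units; within the scatter) shows. The step of an at least 2.2-fold lower number from compound 2 to compound 3 (0.35 log units; beyond the scatter) rests on the limit of compound 2, (the limit of > 100000 nM in this assay, at which 1 of the 3 values shown sits).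

Compound 4, `CC1=CC[C@@H]([C@@](C)(O)CCCC(C)(C)NC(=S)N/N=C\c2ccc(C)cc2)CC1`, has not been measured. It differs from compound 3 in one place: methyl in place of hydrogen on an aromatic carbon. Among the measured compounds shown here, no measured step touches the aromatic ring itself; the two steps that reach the ring, a 1.0-fold higher number from compound 1 to compound 3 (0.01 log units; within the scatter) and an at least 2.2-fold lower number from compound 2 to compound 3 (0.35 log units; beyond the scatter), concern adding the whole arylidene group rather than decorating it. The expectation is therefore a step of a 1.0-fold higher number from compound 3 to compound 4 (0.00 log units; within the scatter), that is, none beyond the scatter. Compound 4 is estimated at 44000 nM, with a likely range from 20000 nM to 100000 nM.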

Compound 4, concentration for total growth inhibition: 39000 nM
Compound 4: middle estimate off by 1.1-fold (0.05 log units), on the high side; the measured number falls inside the stated range.
By their numbers in this assay, from the lowest: compounds 4, 1 and 3 (each within the scatter of the next). At a limit, above all of these: compound 2.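

Among the compounds shown here, until now, no measured step had touched the aromatic ring itself; the earlier steps only added or removed the whole arylidene group. Phenyl to 4-methylphenyl, with the methyl on an aromatic carbon para to a large group, gives in this assay a 1.1-fold lower number from compound 3 to compound 4 (0.05 log units; within the scatter), so this small addition leaves the number within the usual scatter of repeated measurements. The step of an at least 2.5-fold lower number from compound 2 to compound 4 (0.40 log units; beyond the scatter) lies beyond the scatter, as the step to compound 3 did, and it likewise rests on a limit rather than on a plain number, the one belonging to compound 2: the limit of > 100000 nM in this assay, at which 1 of the 4 values shown sits.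

A single methyl group is only one small probe of this ring, so the compounds shown cannot tell whether a methoxy group, a chlorine atom, a nitro group or a carboxylic acid in the same place would also leave the number unchanged. They also leave open whether any change to the aromatic ring can bring growth inhibition beyond the scatter of compound 3, or whether a larger ring such as naphthyl would behave like the phenyl and 4-methylphenyl groups.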